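The source may report more compounds than this note shows. Statements on the series, on what has been measured and on what is new or still open speak of the compounds shown alone.

Three compounds share one core and differ only in the group carried on sulfur. Compound 1 `O=C(O)Cn1c(SCCc2ccccc2)nc2ccccc21` gives 881 nM in an assay on HEK293 cells for displacement of a labelled ligand from prostaglandin D2 receptor 2 (Homo sapiens); on this read-out higher numbers stand for weaker inhibition and lower numbers for stronger inhibition. Compound 2 `CCOC(=O)CCCSc1nc2ccccc2n1CC(=O)O` gives 4410 nM in this assay, and compound 3 `O=C(O)Cn1c(SCc2ccccc2Cl)nc2ccccc21` gives 370 nM. The steps show a 5.0-fold higher number from compound 1 to compound 2 (0.70 log units; beyond the scatter), a 2.4-fold lower number from compound 1 to compound 3 (0.38 log units; beyond the scatter) and a 12-fold lower number from compound 2 to compound 3 (1.08 log units; beyond the scatter). Compound 3 therefore stands lowest of the three, with compound 1 nearest and compound 2 furthest. Compound 4 `O=C(O)Cn1c(SCc2ccccc2Br)nc2ccccc21` differs from compound 3 by bromo in place of chloro on an aromatic carbon. Going by the values given here, none of the measured steps touches a halogen alone: each swaps the whole group on the sulfur, so they give no direct guide to an exchange of one halogen for another on the ring. The two larger steps, a 5.0-fold higher number from compound 1 to compound 2 (0.70 log units; beyond the scatter) and a 12-fold lower number from compound 2 to compound 3 (1.08 log units; beyond the scatter), follow replacement of the aryl group itself, which does not happen here. A change of one halogen for another is expected to stay within the scatter, so compound 4 is expected to give 300 nM, between 120 nM and 750 nM, meaning a 1.2-fold lower number from compound 3 to compound 4 (0.09 log units; within the scatter).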

Compound 4, half-maximal inhibitory concentration: 580 nM
Compound 4: middle estimate off by 1.9-fold (0.29 log units), on the low side; measured number inside the range.
By their numbers in this assay, from the lowest: compounds 3, 4 and 1 (each within the scatter of the next, the first and the last beyond it); then compound 2.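

In this assay, bromo in place of chloro on an aromatic carbon, ortho to a large group, gives a 1.6-fold higher number from compound 3 to compound 4 (0.20 log units; within the scatter), so this single pair does not tell the two halogens apart. The 2-bromophenyl group still stands clear of the ester chain, with a 7.6-fold lower number from compound 2 to compound 4 (0.88 log units; beyond the scatter), but its step against the longer phenyl-bearing chain, a 1.5-fold lower number from compound 1 to compound 4 (0.18 log units; within the scatter), lies within the scatter, whereas the 2-chlorophenyl step, a 2.4-fold lower number from compound 1 to compound 3 (0.38 log units; beyond the scatter), lies beyond it. Nothing available offers an explanation for these steps.

The compounds shown leave open whether hydrogen, fluoro, methoxy or an amine on that same aromatic carbon would read like chloro and bromo. They also leave open how the 2-bromophenyl group would read on a longer chain from the sulfur.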